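Swapping the Amide Aryl Group in an Inactive Pair

The source may report more compounds than this note shows. Statements on the series, on what has been measured and on what is new or still open speak of the compounds shown alone.

Measured compounds:
compound 1, `CS(=O)(=O)c1ccc(C(=O)Nc2ccc(Cl)c(-c3nnc4c(Cl)cccn34)c2)cc1`, > 100000 nM
compound 2, `CS(=O)(=O)c1ccc(C(=O)Nc2ccc(Cl)c(-c3nnc4c(Cl)cccn34)c2)c(Cl)c1`, > 100000 nM

In a functional assay on HeLa cells (Homo sapiens) for antiproliferative activity, read by MTT assay, with a stated time of 72 h (a higher number here means a weaker inhibitor, a lower number a stronger inhibitor), compound 1 gives only a limit, > 100000 nM, not a number. Compound 2 likewise sits at a limit in this assay, > 100000 nM. Among the measured compounds shown here, the one measured step, a step that the two limits leave unreadable from compound 1 to compound 2, therefore cannot be sized: because of the limit of > 100000 nM in this assay, at which 2 of the 2 values shown sit, both values are limits and nothing can be read about the direction or size of that change.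

Compound 3, `O=C(Nc1ccc(Cl)c(-c2nnc3c(Cl)cccn23)c1)c1cccnc1Cl`, has not been measured. It differs from compound 1 by 2-chloropyridin-3-yl in place of 4-(methylsulfonyl)phenyl on a carbonyl carbon. For the measured compounds named here, no measured step touches this part of the molecule, so there is no direct guide to its effect in this assay. What the two measured compounds show is that the shared core of compound 1 gave no activity in this assay with either amide aryl group tried. On that basis the expectation is that compound 3 will again fall at or near the limit, with the step of a number no higher from compound 1 to compound 3 (the limit leaves the size open) expected to be none beyond the scatter. The estimate for compound 3 is 100000 nM, within the range 30000 nM to 300000 nM.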

Compound 3, half-maximal inhibitory concentration: 87500 nM
Compound 3: the middle estimate sits 1.1-fold (0.06 log units) above what was measured; low and high end bracket the measured number.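

Two of the three compounds still stop at a limit rather than a number: the limit of > 100000 nM in this assay, at which 2 of the 3 values shown sit. Among the compounds shown here, compound 3 is the first here to give a real number in this assay, 87500 nM, which shows that a measurable reading is possible on this core when 2-chloropyridin-3-yl stands on the carbonyl carbon. Replacing 4-(methylsulfonyl)phenyl with 2-chloropyridin-3-yl gives an at least 1.1-fold lower number from compound 1 to compound 3 (0.05 log units; that floor lies within the scatter); this is only a floor, so the true gap could be larger, but the data do not establish a change beyond normal scatter.

The swap replaces the whole aryl group at once, so the compounds shown cannot separate the contribution of the ring nitrogen from that of the chlorine in 2-chloropyridin-3-yl, or say which of them, if either, matters. From the compounds shown here alone, it also remains open whether a different group on the same carbonyl carbon, such as an unsubstituted phenyl, a 4-aminophenyl or a 4-carboxyphenyl, would bring the number down well beyond what compound 3 reaches.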